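Fluoro to trifluoromethyl on compound 3

This account rests on a few compounds, and the source may have more. Where it says the series, first, only, none or still open, it means among the compounds named here.

In an ADME assay on microsomes from liver (Homo sapiens) for metabolic stability, read by LC-MS, with a stated time of 30 min, tested at 1 uM (a higher number here means that more of the compound is left, a lower number that less of the compound is left), compound 1 (`O=C(NCc1ccc(S(=O)(=O)c2ccccc2)cc1)c1cc2ccncc2s1`) gives 48% remaining and compound 2 (`O=C(NCc1ccc(S(=O)(=O)c2ccccc2)cc1)c1cc2ncccc2s1`) gives 81% remaining. Among the compounds with values here, the one measured step in the set (a number 33 percentage points higher from compound 1 to compound 2 (beyond the scatter)) exchanges one group for another of equal heavy-atom count on a carbonyl carbon. Compound 3 (`O=C(NCc1ccc(S(=O)(=O)c2cccc(F)c2)cc1)c1cc2cnccc2[nH]1`) stands at 79% remaining, within the scatter of compound 2 and beyond the scatter above compound 1.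

Compound 4 (`O=C(NCc1ccc(S(=O)(=O)c2cccc(C(F)(F)F)c2)cc1)c1cc2cnccc2[nH]1`) carries trifluoromethyl in place of fluoro on an aromatic carbon, the change reading 3-fluorophenyl to 3-(trifluoromethyl)phenyl. The large measured step (a number 33 percentage points higher from compound 1 to compound 2 (beyond the scatter)) lies at a different place in the molecule, so it gives no size for this exchange. It shows only that this assay can move strongly within this series. No measured pair varies the group at the place that changes here, and the range is kept wide for that reason. The expected move is a number 5 percentage points lower from compound 3 to compound 4 (within the scatter) and no step beyond the scatter is expected. For compound 4 the estimate is 74% remaining, with an expected range from 55% to 90% remaining.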

Compound 4, percent of the compound remaining: 81%
Beside the measured number, compound 4's estimate is 7 percentage points below it, within the range that was stated.
By their numbers in this assay, from the lowest: compound 1; then compounds 3, 2 and 4 (each within the scatter of the next).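

In this assay, within the data shown here, the exchange of fluoro for trifluoromethyl on an aromatic carbon, meta to a large group, comes with a number 2 percentage points higher from compound 3 to compound 4 (within the scatter) and is the first reading of any change at this place. Among these compounds, the one earlier step (a number 33 percentage points higher from compound 1 to compound 2 (beyond the scatter)) concerned the group on the carbonyl carbon, so it said nothing about this end of the molecule. Here trifluoromethyl stands in for fluoro without a step beyond the scatter, which so far holds for this single pair, and no measurement at hand offers an explanation for it.

Open, from the compounds shown here alone, is whether this place accepts groups of another kind equally well, such as an amine, a carboxylic acid, a methoxy group or a longer chain, or whether the read-out would move there as strongly as it did at the carbonyl carbon. Also open, going by these compounds, is whether the same exchange of fluoro for trifluoromethyl would read the same on the core of compound 1 or compound 2, where the number depends so strongly on the group on the carbonyl carbon.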